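Swapping Chloro for Bromo on a Shared Core

The source may hold more compounds than are shown below. What is called first, only, known or untested is meant among the compounds shown, and "the series" means these compounds.

Of the compounds shown here, two built on one shared core have so far been measured. Compound 1 `O=C1C(=O)N(CN2CCN(c3ccnc4cc(Cl)ccc34)CC2)c2cc(Cl)ccc21` gives in a functional assay on MDA-MB-468 cells (Homo sapiens) for cytotoxicity, read by sulforhodamine B assay, with a stated time of 48 h (a higher number here means a weaker inhibitor of growth, a lower number a stronger inhibitor of growth), a value of 36600 nM. In this assay compound 2 `NC(=S)N/N=C1/C(=O)N(CN2CCN(c3ccnc4cc(Cl)ccc34)CC2)c2cc(Cl)ccc21` gives 26500 nM. Of the two numbers, compound 2 shows the lower one, yet compound 1 lies within the usual scatter of it, so no order between the two can be read from these figures.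

Compound 3 `NC(=S)N/N=C1/C(=O)N(CN2CCN(c3ccnc4cc(Cl)ccc34)CC2)c2cc(Br)ccc21` differs from compound 2 by bromo in place of chloro on an aromatic carbon. Going by the values given here, no pair of measured compounds shows what such a swap does, since compound 1 and compound 2 differ elsewhere. Compound 3 is therefore expected to stay within the scatter of compound 2, with a step of a 1.1-fold lower number from compound 2 to compound 3 (0.04 log units; within the scatter). Compound 3 is estimated at 24000 nM in this assay, with a range from 12000 nM to 48000 nM.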

Compound 3, concentration for 50% growth inhibition: 11200 nM
Compound 3: middle estimate off by 2.1-fold (0.33 log units), on the high side; the whole stated range lies above it.
By their numbers in this assay, from the lowest: compound 3; then compounds 2 and 1 (each within the scatter of the next).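

In this assay, bromo in place of chloro on an aromatic carbon gives a 2.4-fold lower number from compound 2 to compound 3 (0.37 log units; beyond the scatter) as a modest step, the first one read between measured compounds that differ in one place. It shows that the number responds to which halogen sits at this position, on the six-membered aromatic ring of carbon only, although this rests on a single pair and is no general pattern. No measurement at hand accounts for the step, so it stands as an observation without an explanation.

On these data alone, whether bromo has the same effect on the core of compound 1 remains open. Also open, as far as these compounds go, is how a fluoro, an iodo, a methyl or a methoxy group on this same aromatic carbon would compare with chloro and bromo.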